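Swapping Chloro for Fluoro on a Second Core

The source may hold more compounds than are shown below. What is called first, only, known or untested is meant among the compounds shown, and "the series" means these compounds.

Compound 1, `Cc1cc(C)c2c(O)cc(-c3cccc(F)c3)nc2n1`, gives 33.1 nM in a functional assay on SF-295 cells (Homo sapiens) for antiproliferative activity; a higher number here means a weaker inhibitor of growth, a lower number a stronger inhibitor of growth.
Compound 2, `Cc1cc(C)c2c(O)cc(-c3cccc(Cl)c3)nc2n1`, gives 47.9 nM in this assay.
Compound 3, `Cc1cnc2[nH]c(-c3cccc(Cl)c3)cc(=O)c2c1`, gives 25.1 nM in this assay.

Compound 1 and compound 2 share one core and differ only in fluoro in place of chloro on an aromatic carbon. That change gave a 1.4-fold lower number from compound 2 to compound 1 (0.16 log units; within the scatter), so the two numbers cannot be told apart here. Compound 3 carries a different core; the difference between the two cores is not broken down here. Its number lies close to those of compound 1 and compound 2, all within the usual scatter of one another.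

The unmeasured compound 4, `Cc1cnc2[nH]c(-c3cccc(F)c3)cc(=O)c2c1`, arises from compound 3 by fluoro in place of chloro on an aromatic carbon. Among the compounds with values here, this is the same change as the one from compound 2 to compound 1, and the place of the change is described in the same words in both cases. In this assay the step from compound 3 to compound 4 is expected to be small, a 1.3-fold lower number from compound 3 to compound 4 (0.10 log units; within the scatter), because a 1.4-fold lower number from compound 2 to compound 1 (0.16 log units; within the scatter) stayed within the scatter. Compound 4 is therefore estimated at 20 nM, with a likely range from 8 nM to 50 nM.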

Compound 4, concentration for 50% growth inhibition: 27.5 nM
Estimate against measurement, compound 4: 1.4-fold (0.14 log units) below; measured number inside the range.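

On the core of compound 3, fluoro in place of chloro on an aromatic carbon gave a 1.1-fold higher number from compound 3 to compound 4 (0.04 log units; within the scatter), so compound 3 and compound 4 cannot be told apart in this assay. Set beside the earlier step, the swap left the number within the scatter on both cores, and the two steps cannot be told apart either: the same change on two cores in this assay, a 1.4-fold lower number (0.16 log units; within the scatter) from compound 2 to compound 1 and a 1.1-fold higher number (0.04 log units; within the scatter) from compound 3 to compound 4, 1.6-fold (0.20 log units) apart, within the scatter of two such steps

This shows that, on these two cores, trading chloro for fluoro made no readable difference to growth inhibition, but it does not show that either group is better, and steps this small cannot reveal whether a core shapes the effect of the change.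

The compounds shown carry only fluoro or chloro at this place, so it remains open what a methoxy group, an amine or a carboxylic acid would do there. As far as these compounds go, it also remains open whether a change with a step beyond the scatter would carry from one core to the other as faithfully.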